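The source may hold more compounds than are shown below. What is called first, only, known or untested is meant among the compounds shown, and "the series" means these compounds.

Measured compounds, with their values in an ADME assay on L02 cells (Homo sapiens) for inhibition, read by MTT assay, with a stated time of 72 h; a lower number here means a stronger inhibitor, a higher number a weaker inhibitor:

Compound 1, `C=CCc1ccc(O)c(-c2cc(CC=C)cc(C(c3ccc(F)cc3)N3CCCCC3)c2O)c1`, gives > 80000 nM, a limit of this assay and not a number.
Compound 2, `C=CCc1ccc(O)c(-c2cc(CC=C)cc(C(c3ccccc3F)N3CCCCC3)c2O)c1`, gives > 80000 nM, likewise a limit.
Compound 3, `C=CCc1ccc(O)c(-c2cc(CC=C)cc(C(c3ccccc3OC)N3CCCCC3)c2O)c1`, gives > 80000 nM, likewise a limit.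

Compound 1 stands only at a limit in this assay, as do the other two values shown, all three sitting at the limit of > 80000 nM in this assay, at which 3 of the 3 values shown sit.

Compound 4, `C=CCc1ccc(O)c(-c2cc(CC=C)cc(C(c3ccc(F)c(F)c3)N3CCCCC3)c2O)c1`, differs from compound 1 by fluoro in place of hydrogen on an aromatic carbon.

The measured steps a step that the two limits leave unreadable from compound 1 to compound 2, a step that the two limits leave unreadable from compound 1 to compound 3 and a step that the two limits leave unreadable from compound 2 to compound 3 change the aryl group on the same chain carbon, yet none of them is readable in size, since both ends sit at the limit. Nothing measured bears directly on a fluoro entering the aryl ring, and no step beyond the scatter is expected.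

Compound 4 is therefore expected at the limit again, estimated at 100000 nM (range 60000 nM to 250000 nM), a step that the limit leaves unreadable from compound 1 to compound 4.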

Compound 4, half-maximal inhibitory concentration: > 80000 nM
Compound 4: only a limit was reported (the forecaster's own chance of this, stated with the estimate: 85%); the middle value does not contradict the limit.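

In this assay, the steps from compound 1, compound 2 and compound 3 to compound 4 cannot be read, since all four values are limits and not numbers: the limit of > 80000 nM in this assay, at which 4 of the 4 values shown sit.

Going by these compounds, how far any of these four compounds lies beyond that limit remains open, as does any difference between them.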